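Trading an isopropyl for a hydrogen at the assay limit

This account rests on a few compounds, and the source may have more. Where it says the series, first, only, none or still open, it means among the compounds named here.

Within the data shown here, only two measurements exist so far, both from a functional assay on A549 cells (Homo sapiens) for antiproliferative activity, read by sulforhodamine B assay, with a stated time of 72 h; on this read-out lower numbers stand for stronger inhibition and higher numbers for weaker inhibition. In this test, compound 1 (`CCOc1ccc(O)c(C(=O)/C=C/c2csc3ccccc23)c1`) gives 5400 nM. Compound 2 (`COc1c(OC(C)C)cc2c(c1OC(C)C)C(=O)/C(=C/c1csc3ccccc13)O2`) gives only a limit, > 10000 nM, and not an exact number.

Compound 3 (`COc1c(OC(C)C)cc2c(c1O)C(=O)/C(=C/c1csc3ccccc13)O2`) differs from compound 2 in one place: hydrogen in place of isopropyl on an oxygen on an aromatic ring. Hydrogen stands in place of isopropyl on an oxygen on an aromatic ring, so an isopropoxy group becomes a hydroxy group.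

Among the measured compounds shown here, no measured pair of compounds shows this change, and the starting point is a limit, so any forecast is loose. In this assay, a modest move toward stronger inhibition is expected, rather than a large one. That expectation leans only on compound 1 at 5400 nM, which shows that a measurable value is possible within this small set. Another result at the limit would be no surprise. The expected step is an at least 2.0-fold lower number from compound 2 to compound 3 (0.30 log units; that floor lies within the scatter). For compound 3, the estimated value is 5000 nM, with an expected range of 1200 nM to 12000 nM.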

Compound 3, half-maximal inhibitory concentration: > 10000 nM
Compound 3: no number, only a limit; the forecaster's own chance of this, stated with the estimate: 40%; middle value at least 2.0-fold (0.30 log units) from the limit.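

In this assay compound 3 gives only a limit, > 10000 nM, and not an exact number. No step can be read from compound 2 to compound 3, because both sit at the same limit: the limit of > 10000 nM in this assay, at which 2 of the 3 values shown sit. As far as these compounds go, whether hydroxy in place of isopropoxy changes inhibition at all, and by how much, stays open.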